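A few compounds are considered here, and "the series" means these few. Any claim that something is new, unique, unknown or untested is made for them only; others in the source may bear on it.

Measured compounds and their values in a physicochemical assay for solubility, read by LC-MS, in phosphate buffer, with a stated time of 24 h, at pH 7.4; a higher number here means a more soluble compound, a lower number a less soluble compound:

compound 1, `O=C(Nc1ccccc1)c1cnc(NCc2c(F)ccc3c2CCO3)n2cnnc12`: < 1000 nM
compound 2, `Cc1ncc(-c2cnc(NCc3c(F)ccc4c3CCO4)c3cn[nH]c(=O)c23)n1C`: 15000 nM
compound 3, `Cc1ncccc1-c1cnc(NCc2c(F)ccc3c2CCO3)n2c(=O)[nH]nc12`: < 2000 nM

Compound 2 is the only one of the three for which this assay returned a number. For compound 1 the value < 1000 nM is a limit of the assay, not a number, as noted in the limit of < 1000 nM in this assay, at which 1 of the 3 values shown sits. For compound 3 the value < 2000 nM is likewise a limit, as noted in the limit of < 2000 nM in this assay, at which 1 of the 3 values shown sits. Among the measured compounds shown here, compound 2 therefore stands alone as the measured reference point, and no step between two measured compounds can be drawn from these three.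

The unmeasured compound 4 is `Cc1nn(C)cc1-c1cnc(NCc2c(F)ccc3c2CCO3)c2cn[nH]c(=O)c12`. It differs from compound 2 in one place: 1,3-dimethyl-1H-pyrazol-4-yl in place of 1,2-dimethyl-1H-imidazol-5-yl on an aromatic carbon. The two compounds have the same atoms, joined differently.

For the measured compounds named here, with no measured step to lean on, compound 4 is expected to lie somewhat under compound 2 in this assay, by an amount that may reach just beyond the scatter, giving an expected step of a 2.5-fold lower number from compound 2 to compound 4 (0.40 log units; beyond the scatter). The estimate for compound 4 is 6000 nM, within a range from 2000 nM to 20000 nM.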

Compound 4, solubility: 9000 nM
For compound 4 the middle estimate is 1.5-fold (0.18 log units) below the measured one, and the stated range covers the measured number.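

In this assay, among the compounds shown here, the exchange gives a 1.7-fold lower number from compound 2 to compound 4 (0.22 log units; within the scatter), the first comparison in which only one place on the shared core differs. At this place, on an aromatic carbon para to a large group, 1,3-dimethyl-1H-pyrazol-4-yl and 1,2-dimethyl-1H-imidazol-5-yl cannot be told apart in this read-out, and compound 4 joins compound 2 as a second compound with a number rather than a limit of the assay. Nothing shown here bears on what lies behind this small step.

From the compounds shown here alone, it remains open how a group of another kind at this place, such as a carboxylic acid or an aliphatic amine, would read in this assay. Going by these compounds, it also remains open whether the same exchange would read alike on the core of compound 1 or compound 3.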